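Benzoyl thiourea series on the fused core: substituent steps

This account rests on a few compounds, and the source may have more. Where it says the series, first, only, none or still open, it means among the compounds named here.

Three members of the series are in hand, all sharing one core and a benzoyl thiourea arm. Compound 1 `Nc1ccc2sc(NC(=S)NC(=O)c3ccccc3)nc2c1` carries an amino group on the core; in a functional assay on MCF7 cells (Homo sapiens) for cytotoxicity, read by MTT assay, with a stated time of 24 h (on this read-out lower numbers stand for stronger inhibition and higher numbers for weaker inhibition), compound 1 gives 38600 nM. Compound 2 `O=C(NC(=S)Nc1nc2cc([N+](=O)[O-])ccc2s1)c1ccccc1` carries a nitro group in the same place, and in this assay compound 2 gives 41600 nM. Compound 3 `O=C(NC(=S)Nc1nc2cc(Br)ccc2s1)c1ccccc1` carries a bromo group there, and in this assay compound 3 gives 32100 nM.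

Compound 2 has the highest of the three numbers, yet both its neighbours sit within the scatter: a 1.1-fold higher number from compound 1 to compound 2 (0.03 log units; within the scatter), a 1.3-fold lower number from compound 2 to compound 3 (0.11 log units; within the scatter), and a 1.2-fold lower number from compound 1 to compound 3 (0.08 log units; within the scatter). Swapping the group on the core thus moves nothing that can be resolved.

Compound 4 `O=C(NC(=S)Nc1nc2cc([N+](=O)[O-])ccc2s1)c1ccc([N+](=O)[O-])cc1` is the next candidate. Relative to compound 2 the change is nitro in place of hydrogen on an aromatic carbon. Among the measured compounds shown here, no measured step alters this six-membered aromatic ring of carbon only; the three steps recorded all touch the core instead. For the measured compounds named here, they are the only guide, and each of them was flat. The expectation for this assay is therefore a step of about a 1.0-fold lower number from compound 2 to compound 4 (0.02 log units; within the scatter), that is, nothing beyond the scatter in either direction. Compound 4 is expected to give roughly 40000 nM, with a range from 18000 nM to 90000 nM.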

Compound 4, half-maximal inhibitory concentration: 35200 nM
Estimate against measurement, compound 4: 1.1-fold (0.06 log units) above; low and high end bracket the measured number.
By their numbers in this assay, from the lowest: compounds 3, 4, 1 and 2 (each within the scatter of the next).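

Phenyl to 4-nitrophenyl is the first change on the six-membered aromatic ring of carbon only, and in this assay it gives a 1.2-fold lower number from compound 2 to compound 4 (0.07 log units; within the scatter). The insensitivity seen so far on the core therefore also holds for this one change on the second ring: nitro in place of hydrogen, para to a large group, does not resolve from hydrogen, and the four compounds form a chain in which each number lies within the scatter of the next. Nothing in hand speaks to a cause for this result.

As far as these compounds go, the step is read only with nitro on the core, so whether the same change stays flat with amino or bromo there remains open. Also open, from the compounds shown here alone, is whether a carboxylic acid, a methoxy group or a longer alkyl chain on this ring, or a nitro group elsewhere on it, would move the number beyond the scatter.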